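Replacing benzyl with 2-(pyrrolidin-1-yl)ethyl on compound 3

The source may hold more compounds than are shown below. What is called first, only, known or untested is meant among the compounds shown, and "the series" means these compounds.

Compound 1 `CN/C(=N\C1=NC(=O)C(=O)N1C(C)C)Nc1ccc(Cl)c(Cl)c1` gives > 1 h as a limit
Compound 2 `CC(C)N1C(=O)C(=O)N=C1/N=C(/Nc1ccc(Cl)c(Cl)c1)NC(C)(C)C` gives > 1 h as a limit
Compound 3 `CC(C)N1C(=O)C(=O)N=C1/N=C(\NCc1ccccc1)Nc1ccc(Cl)c(Cl)c1` gives > 1 h as a limit

In an in vitro ADME assay on microsomes from liver (Mus musculus) for metabolic stability, read by LC-MS (on this read-out lower numbers stand for a shorter-lived compound and higher numbers for a longer-lived compound), compound 3 stands at > 1 h as a limit, not a number. All three compounds share it (the limit of > 1 h in this assay, at which 3 of the 3 values shown sit). Compound 4 `CC(C)N1C(=O)C(=O)N=C1/N=C(\NCCN1CCCC1)Nc1ccc(Cl)c(Cl)c1` carries one change ((pyrrolidin-1-yl)methyl in place of phenyl on a saturated chain carbon bound to an amine nitrogen), so benzyl becomes 2-(pyrrolidin-1-yl)ethyl. The closest measured steps are a step that the two limits leave unreadable from compound 1 to compound 3 and a step that the two limits leave unreadable from compound 2 to compound 3, which also change the group on this amine nitrogen, yet neither gives a size or direction. With nothing to carry over, the expected step in this assay is a step that the limit leaves unreadable from compound 3 to compound 4, no larger than the scatter. For compound 4 the estimate is 1.2 h, with an expected range of 0.4 h to 3 h here.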

Compound 4, half-life: > 1 h
Compound 4 was reported as a limit (the forecaster's own chance of this, stated with the estimate: 60%); the middle value is on the limit's open side.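

No step from compound 1, compound 2 or compound 3 to compound 4 can be read in this assay, because all of these compounds share one limit: the limit of > 1 h in this assay, at which 4 of the 4 values shown sit.

As far as these compounds go, how long each compound actually lasts, and whether any of these group changes alters that, stays open.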